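Adding a Methoxy Group: Expected Cytotoxicity of Compound 4

The source may report more compounds than this note shows. Statements on the series, on what has been measured and on what is new or still open speak of the compounds shown alone.

This account concerns three compounds tested in an ADME assay on HepG2 cells (Homo sapiens) for cytotoxicity, read by resazurin assay, with a stated time of 24 h (on this read-out lower numbers stand for higher toxicity in this test and higher numbers for lower toxicity in this test), and a fourth not yet measured. Compound 1 `COc1cccc(C=Cc2ccc3ccccc3c2)c1C(=O)O` carries a methoxy group and a carboxy group on its core. In this assay compound 1 gives > 100000 nM, which is a limit of the assay and not a number. Compound 2 `O=C(O)c1c(O)cccc1/C=C/c1ccccc1` returns > 100000 nM in this assay, again a limit. Compound 3 `O=C(O)c1c(O)cccc1CCc1ccccc1` likewise returns > 100000 nM, also a limit. Compound 1 thus stands where every measured value sits, at the limit of > 100000 nM in this assay, at which 3 of the 3 values shown sit, so no ordering among the three can be drawn.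

Compound 4 `COc1cc(C=Cc2ccc3ccccc3c2)c(C(=O)O)c(OC)c1` differs from compound 1 by methoxy in place of hydrogen on an aromatic carbon. Within the data shown here, no step between measured compounds is available to guide this change. Because compound 1 reaches only the limit > 100000 nM in this assay, the expectation is that the step that the limit leaves unreadable from compound 1 to compound 4 amounts to nothing beyond the scatter. Compound 4 is therefore estimated at 150000 nM, with a range from 70000 nM to 400000 nM, and is expected most likely to be reported again only as a limit.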

Compound 4, half-maximal cytotoxic concentration: > 100000 nM
Compound 4 gave a limit, no number; the forecaster's own chance of this, stated with the estimate: 85%; the middle value is on the limit's open side.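

No new step can be read from compound 1 to compound 4, since both are reported only as limits: the limit of > 100000 nM in this assay, at which 4 of the 4 values shown sit. The compounds shown leave open how far any of the four lies beyond that limit, and whether methoxy in place of hydrogen changes the read-out at all.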